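Aryl swap from compound 2 to compound 3

The source may hold more compounds than are shown below. What is called first, only, known or untested is meant among the compounds shown, and "the series" means these compounds.

Among the compounds with values here, in a functional assay (muscle tissue) with Cavia porcellus as the target (on this read-out higher numbers stand for an effect only at larger amounts of compound and lower numbers for an effect already at smaller amounts), compound 1 (`COC(=O)C1=C(C)N=C(C)/C(=C(\O)OC)C1c1cc(Cl)cc(Cl)c1`) gives 93.3 nM and compound 2 (`COC(=O)C1=C(C)N=C(C)/C(=C(\O)OC)C1c1ccc(F)cc1`) gives 129 nM on the same read-out, so compound 2 sits within the scatter of compound 1, the only other number in hand. Compound 3 (`COC(=O)C1=C(C)N=C(C)/C(=C(\O)OC)C1c1ccccc1OC`) is not yet measured. It carries 2-methoxyphenyl in place of 4-fluorophenyl on a saturated ring carbon. Within the data shown here, the only measured step bearing on this exchange changes the group at that same carbon, and its size is a 1.4-fold higher number from compound 1 to compound 2 (0.14 log units; within the scatter) in the series so far. Among the measured compounds shown here, no measured compound carries 2-methoxyphenyl, so this guidance is thin. A step beyond the scatter in this assay is not expected, and neither direction is favoured. The estimate amounts to a 1.1-fold lower number from compound 2 to compound 3 (0.03 log units; within the scatter) as the expected step. Compound 3 is estimated at 120 nM with an expected range of 35 nM to 420 nM as the likely span.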

Compound 3, half-maximal effective concentration: 57.5 nM
Compound 3: the middle estimate sits 2.1-fold (0.32 log units) above what was measured; the measured number falls inside the stated range.
By their numbers in this assay, from the lowest: compounds 3, 1 and 2 (each within the scatter of the next, the first and the last beyond it).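

In this assay, the group on the saturated ring carbon now gives its first step beyond the scatter, though a modest one, with 2-methoxyphenyl replacing 4-fluorophenyl: a 2.2-fold lower number from compound 2 to compound 3 (0.35 log units; beyond the scatter). Within the data shown here, the same group in place of 3,5-dichlorophenyl stays within the scatter at a 1.6-fold lower number from compound 1 to compound 3 (0.21 log units; within the scatter), so only the pair of compound 2 and compound 3 separates at this position. No measurement on hand accounts for the step.

The swap from compound 2 to compound 3 both removes the fluorine and introduces the methoxy group, and the compounds shown do not separate these two changes. Also open, from the compounds shown here alone, is how this position responds to an aryl group carrying an amine, a carboxylic acid or a nitrile.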